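Second Chlorine at the Same Place: Expected Effect

The source may hold more compounds than are shown below. What is called first, only, known or untested is meant among the compounds shown, and "the series" means these compounds.

Of the compounds shown here, two sharing one core have been measured. In a functional assay on MNK45 cells (Homo sapiens) for inhibition, read by MTT assay, with a stated time of 48 h (on this read-out lower numbers stand for stronger inhibition and higher numbers for weaker inhibition), compound 2 `Cc1ccc(NC(=S)NC(=O)c2ccc(OCc3ccccc3Cl)cc2)cc1-c1nc2ccccc2[nH]1` gives 51400 nM, the highest of the two numbers. Its nearest neighbour, compound 1 `Cc1ccc(NC(=S)NC(=O)c2ccc(OCc3cccc(Cl)c3)cc2)cc1-c1nc2ccccc2[nH]1`, gives 43300 nM in this assay. Among the measured compounds shown here, the only measured step, a 1.2-fold higher number from compound 1 to compound 2 (0.07 log units; within the scatter), moves the chlorine around the same ring that is changed here and stays within the scatter. Compound 3 `Cc1ccc(NC(=S)NC(=O)c2ccc(OCc3ccc(Cl)c(Cl)c3)cc2)cc1-c1nc2ccccc2[nH]1` differs from compound 2 by 3,4-dichlorophenyl in place of 2-chlorophenyl on a saturated chain carbon bound to an oxygen on an aromatic ring. For the measured compounds named here, no measured step adds a second chlorine at this place, so the expectation rests only on the step from compound 1 to compound 2 being within the scatter. Compound 3 is therefore expected to give about 40000 nM in this assay, with a range from 14000 nM to 115000 nM. The expected step of a 1.3-fold lower number from compound 2 to compound 3 (0.11 log units; within the scatter) is no change beyond the scatter, in either direction.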

Compound 3, half-maximal inhibitory concentration: 8410 nM
For compound 3 the middle estimate is 4.8-fold (0.68 log units) above the measured one, and the stated range ends above it.
By their numbers in this assay, from the lowest: compound 3; then compounds 1 and 2 (each within the scatter of the next).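

In this assay, among the compounds shown here, the earlier compounds showed only that a single chlorine on this ring could sit in either of two places with no change beyond the scatter. The new result shows that this part of the molecule can still affect the read-out: putting chloro in place of hydrogen on an aromatic carbon of the 3-chlorophenyl group gives a 5.1-fold lower number from compound 1 to compound 3 (0.71 log units; beyond the scatter) in this series. Replacing 2-chlorophenyl with 3,4-dichlorophenyl at the same place gives a similar result, a 6.1-fold lower number from compound 2 to compound 3 (0.79 log units; beyond the scatter) on the same read-out, so both single-place comparisons point the same way, though both steps are modest and the numbers remain high.

On these data alone, it remains open whether other groups on this ring, such as methoxy or trifluoromethyl, would lower the number further or raise it. Nothing shown here explains why the second chlorine lowers the number.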